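The source may hold more compounds than are shown below. What is called first, only, known or untested is meant among the compounds shown, and "the series" means these compounds.

In a functional assay on MDA-MB-435 cells (Homo sapiens) for antiproliferative activity, read by sulforhodamine B assay, with a stated time of 72 h (on this read-out lower numbers stand for stronger inhibition and higher numbers for weaker inhibition), three compounds have been measured so far. Compound 1 `O=S(=O)(Nc1ncccn1)c1ccc(Nc2nncc3ccccc23)cc1` gives 45 nM and compound 3 `O=S(=O)(Nc1nccs1)c1ccc(Nc2nncc3ccccc23)cc1` gives 36 nM, so these two stand together within the scatter. Compound 2 `Clc1ccc(C(/C=C/c2ccccc2)=N\Nc2nncc3ccccc23)cc1`, which carries no sulfonamide, gives 5.6 nM, a number clearly lower than that of compound 3.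

Compound 4 `Cc1cc(NS(=O)(=O)c2ccc(Nc3nncc4ccccc34)cc2)no1` departs from compound 3 at a single place, on a sulfonamide nitrogen, with 5-methyl-1,2-oxazol-3-yl in place of 1,3-thiazol-2-yl on a sulfonamide nitrogen. Going by the values given here, only one measured step bears on this, an exchange at the same place: a 1.3-fold lower number from compound 1 to compound 3 (0.10 log units; within the scatter). That step stayed within the scatter, and compound 2 differs too widely to help. A single step is thin evidence and does not favour a direction, so no shift beyond the scatter is expected in this assay. The expected step is small, a 1.1-fold higher number from compound 3 to compound 4 (0.05 log units; within the scatter). The estimated value for compound 4 is 40 nM, with an expected range from 15 nM to 110 nM.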

Compound 4, half-maximal inhibitory concentration: 27 nM
For compound 4 the middle estimate is 1.5-fold (0.17 log units) above the measured one, within the range that was stated.
By their numbers in this assay, from the lowest: compound 2; then compounds 4, 3 and 1 (each within the scatter of the next).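

In this assay, the change to 5-methyl-1,2-oxazol-3-yl on the sulfonamide nitrogen gives a 1.3-fold lower number from compound 3 to compound 4 (0.12 log units; within the scatter), and measured against the pyrimidin-2-yl group it gives a 1.7-fold lower number from compound 1 to compound 4 (0.22 log units; within the scatter). Both steps stay within the scatter, so a third ring group, this one carrying a methyl and with oxygen in place of the sulfur of 1,3-thiazol-2-yl, extends what compound 1 and compound 3 alone had shown: at this place, the exchanges so far leave the number essentially unmoved. No measurement at hand explains this insensitivity. Still open, going by these compounds, is whether the position stays this flat for groups of another kind, such as a plain phenyl ring, an open alkyl chain, or a carboxylic acid or amine carried on the ring.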